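This account rests on a few compounds, and the source may have more. Where it says the series, first, only, none or still open, it means among the compounds named here.

Compounds measured so far:
compound 1 `COc1ccc(-c2cc(NC(=O)COCC(=O)N(C)CC(=O)NC(C)(C)C)nc(-c3ccc(OC)cc3)n2)cc1` gives 7200 nM in an assay on HeLa cells for displacement of a labelled ligand from adenosine receptor A3 (Homo sapiens), read by fluorescence polarization, with a stated time of 30 min; a lower number here means a stronger inhibitor, a higher number a weaker inhibitor;
compound 2 `COc1ccc(-c2cc(NC(=O)COCC(=O)N(C)CC(=O)NC3CCCCC3)nc(-c3ccc(OC)cc3)n2)cc1` gives 10100 nM in this assay.

Compound 2 holds the higher of the two numbers in this assay; its nearest neighbour is compound 1, and the step of a 1.4-fold higher number from compound 1 to compound 2 (0.15 log units; within the scatter) lies within the scatter. The move from compound 2 to compound 3 `COc1ccc(-c2cc(NC(=O)COCC(=O)N(C)CC(=O)NCc3ccccc3)nc(-c3ccc(OC)cc3)n2)cc1` changes one group at the same place: benzyl in place of cyclohexyl on an amide-type nitrogen. Within the data shown here, the only measured step that bears on this place is a 1.4-fold higher number from compound 1 to compound 2 (0.15 log units; within the scatter), an exchange of one group on the amide-type nitrogen for another, which stayed within the scatter. Among the measured compounds shown here, no measured pair shows a benzyl at this position, so the bearing is indirect. For the measured compounds named here, since the one exchange seen at this nitrogen did not move the number beyond the scatter, compound 3 is expected to stand close to compound 2, with the estimated step of a 1.1-fold lower number from compound 2 to compound 3 (0.05 log units; within the scatter) not beyond the scatter. The expected value for compound 3 in this assay is 9000 nM, within a range from 3500 nM to 23000 nM.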

Compound 3, inhibition constant: 19000 nM
Beside the measured number, compound 3's estimate is 2.1-fold (0.32 log units) below it; low and high end bracket the measured number.
By their numbers in this assay, from the lowest: compounds 1, 2 and 3 (each within the scatter of the next, the first and the last beyond it).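

In this assay, among these compounds, the exchange of cyclohexyl for benzyl on the amide-type nitrogen gives a 1.9-fold higher number from compound 2 to compound 3 (0.27 log units; within the scatter) and so remains within the scatter, whereas benzyl in place of tert-butyl gives a 2.6-fold higher number from compound 1 to compound 3 (0.42 log units; beyond the scatter) and is the first step at this nitrogen to pass beyond it, though only modestly. The group on this nitrogen can therefore change the number measurably, but compound 2 lies within the scatter of both compound 1 and compound 3, so only the two outer compounds of the series can be told apart. No information is available that would account for the difference between the benzyl and tert-butyl compounds.

The compounds shown leave open whether a group that keeps the ring but lengthens the chain, such as phenethyl, or a benzyl carrying a methoxy group or an amine on its ring, would shift the number further in either direction. They also leave open how a much smaller group, such as methyl, would compare with tert-butyl at this nitrogen.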